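The source may hold more compounds than are shown below. What is called first, only, known or untested is meant among the compounds shown, and "the series" means these compounds.

Measured compounds and their values:
compound 1 `CCc1cccc(NC(=O)N[C@H](C)c2ccccc2)c1`, 36%
compound 2 `C[C@@H](NC(=O)Nc1cccc(F)c1)c1ccccc1`, 84%
compound 3 `C[C@@H](NC(=O)Nc1cccc(Cl)c1)c1ccccc1`, 83%

In an ADME assay on the whole organism with Oryza sativa as the target, tested at 10 uM (on this read-out lower numbers stand for a stronger effect and higher numbers for a weaker effect at the one concentration tested), compound 2 and compound 3 lie within the scatter of each other (a number 1 percentage points lower from compound 2 to compound 3 (within the scatter)), and both stand far from compound 1 (a number 48 percentage points higher from compound 1 to compound 2 (beyond the scatter), a number 47 percentage points higher from compound 1 to compound 3 (beyond the scatter)). Compound 4 `C[C@@H](NC(=O)Nc1ccc(F)c(F)c1)c1ccccc1` is not yet measured; it differs from compound 2 by fluoro in place of hydrogen on an aromatic carbon. Among the measured compounds shown here, no measured step adds a group to a ring that already carries one. For the measured compounds named here, the only step at the substituted position, chloro in place of fluoro, stayed within the scatter, whereas the large steps all concern ethyl giving way to a halogen. The expected step is therefore a number 4 percentage points lower from compound 2 to compound 4 (within the scatter), within the scatter. Compound 4 is estimated at 80%, between 60% and 95%.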

Compound 4, a percentage reported as activity, at one concentration (the size of the read-out at that concentration, not a potency): 96%
Compound 4: the middle estimate sits 16 percentage points below what was measured; the whole stated range lies below it.
By their numbers in this assay, from the lowest: compound 1; then compounds 3 and 2 (each within the scatter of the next); then compound 4.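

In this assay, placing a fluoro group on a ring that already carries one gives a number 12 percentage points higher from compound 2 to compound 4 (beyond the scatter), a shift toward a weaker effect. Thus, a single added fluorine ortho to a fluoro group and para to a large group can move the read-out beyond the scatter, although this step is modest beside the large steps from ethyl to halogen. Nothing available explains this shift. Going by these compounds, it remains open whether a chloro, methoxy or amine group at this position would shift the read-out in the same direction.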